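The source may hold more compounds than are shown below. What is called first, only, known or untested is meant among the compounds shown, and "the series" means these compounds.

In a functional assay on L6 cells (Rattus norvegicus) for inhibition (on this read-out higher numbers stand for weaker inhibition and lower numbers for stronger inhibition), compound 1, `CC(C)c1c(C(=O)N(C)Cc2ccccc2)nn(-c2ccc(F)cc2)c1OC[C@@H](O)C[C@@H](O)CC(=O)O`, gives 6720 nM. Compound 2, `CC(C)c1c(C(=O)N2CCC[C@H](c3ccccc3)C2)nn(-c2ccc(F)cc2)c1OC[C@@H](O)C[C@@H](O)CC(=O)O`, gives 1110 nM. Compound 3, `CC(C)c1c(C(=O)NCc2ccc(Cl)cc2)nn(-c2ccc(F)cc2)c1OC[C@@H](O)C[C@@H](O)CC(=O)O`, is recorded as "not determined" (no result reported) in this assay.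

Compound 1 stands as the higher of the two numbers in this assay; its nearest neighbour, compound 2, lies a 6.1-fold lower number from compound 1 to compound 2 (0.78 log units; beyond the scatter) below it. Compound 4, `CC(C)c1c(C(=O)N(C)Cc2ccc(F)c(F)c2)nn(-c2ccc(F)cc2)c1OC[C@@H](O)C[C@@H](O)CC(=O)O`, differs from compound 1 by 3,4-difluorophenyl in place of phenyl on a saturated chain carbon bound to an amide-type nitrogen. For the measured compounds named here, no measured step describes this change: the only step on record, a 6.1-fold lower number from compound 1 to compound 2 (0.78 log units; beyond the scatter), replaces the whole amine part and so does not bear on it. The expectation for compound 4 is therefore a step no larger than the scatter, a 1.3-fold lower number from compound 1 to compound 4 (0.13 log units; within the scatter), in either direction. Compound 4 is thus estimated at 5000 nM, within 2000 nM to 15000 nM.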

Compound 4, half-maximal inhibitory concentration: 4570 nM
Compound 4: middle estimate off by 1.1-fold (0.04 log units), on the high side; the measured number falls inside the stated range.
By their numbers in this assay, from the lowest: compound 2; then compounds 4 and 1 (each within the scatter of the next).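

In this assay, the change from phenyl to 3,4-difluorophenyl on a saturated chain carbon bound to an amide-type nitrogen gives a 1.5-fold lower number from compound 1 to compound 4 (0.17 log units; within the scatter) and so leaves the read-out unresolved from that of the unsubstituted benzyl amide. The replacement of the whole amine part remains the larger effect, with a 4.1-fold higher number from compound 2 to compound 4 (0.61 log units; beyond the scatter) showing that the 3-phenylpiperidin-1-yl amide keeps its separation from this fluorinated amide. Nothing on hand explains either step. On these data alone, whether a methoxy group or a single chlorine on this phenyl would behave the same way remains open, as does the effect of 3,4-difluorophenyl on the 3-phenylpiperidin-1-yl amide.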